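Methoxycarbonyl in place of (allylcarbamoyl)methyl in compound 2

The source may report more compounds than this note shows. Statements on the series, on what has been measured and on what is new or still open speak of the compounds shown alone.

Measured in a functional assay on MCF7 cells (Homo sapiens) for inhibition; a higher number here means a weaker inhibitor, a lower number a stronger inhibitor:
Compound 1 `CCCCCCCC[C@@]1(C)SC(=O)C=C1OC` gives > 50 ug/mL as a limit
Compound 2 `C=CCNC(=O)COC1=CC(=O)S[C@]1(C)CCCCCCCC` gives > 50 ug/mL as a limit

Compound 2 therefore stands at a limit and has no number of its own. The evidence amounts to the limit of > 50 ug/mL in this assay, at which 2 of the 2 values shown sit, and nothing more. Compound 3 `CCCCCCCC[C@@]1(C)SC(=O)C=C1OC(=O)OC` carries methoxycarbonyl in place of (allylcarbamoyl)methyl on an oxygen on an unsaturated carbon in the shared core. Within the data shown here, the only measured step is a step that the two limits leave unreadable from compound 1 to compound 2 and gives no size to build on, so no step beyond the scatter is expected in this assay here. The expected step is a step that the limit leaves unreadable from compound 2 to compound 3 on this estimate. For compound 3 the estimated value is 60 ug/mL with an expected range from 30 ug/mL to 120 ug/mL in this assay.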

Compound 3, half-maximal inhibitory concentration: 10.7 ug/mL
Beside the measured number, compound 3's estimate is 5.6-fold (0.75 log units) above it, and the stated range ends above it.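

Of the three groups on the oxygen on an unsaturated carbon, only methoxycarbonyl gives a readable number in this assay, with an at least 4.6-fold lower number from compound 2 to compound 3 (0.66 log units; beyond the scatter) as its step against the (allylcarbamoyl)methyl group. Set against methyl at the same place, it gives an at least 4.6-fold lower number from compound 1 to compound 3 (0.66 log units; beyond the scatter) as the step. Both steps are minimum sizes because compound 1 and compound 2 each stand at a limit: the limit of > 50 ug/mL in this assay, at which 2 of the 3 values shown sit.

Going by these compounds, whether acetyl or ethoxycarbonyl on this oxygen would give a comparable number stays open, as does the effect of an amine-bearing chain there.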